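Nitro to Nitrile on Two Cores: Expecting Compound 4

The source may report more compounds than this note shows. Statements on the series, on what has been measured and on what is new or still open speak of the compounds shown alone.

Of the compounds shown here, three have been measured in a functional assay on CWR22R cells (Homo sapiens) for antiproliferative activity, read by propidium iodide staining, with a stated time of 96 h; on this read-out higher numbers stand for weaker inhibition and lower numbers for stronger inhibition. Compound 1 `CC(O)(COc1ccc(S(F)(F)(F)(F)F)cc1)C(=O)Nc1ccc(C#N)cc1C(F)(F)F` gives 14700 nM, and compound 2 `CC(O)(COc1ccc(S(F)(F)(F)(F)F)cc1)C(=O)Nc1ccc([N+](=O)[O-])cc1C(F)(F)F` gives 17100 nM. These two share one core, and the change between them is cyano in place of nitro on an aromatic carbon; it made a 1.2-fold lower number from compound 2 to compound 1 (0.07 log units; within the scatter). Compound 3 `CC1(C)C(=O)N(c2ccc([N+](=O)[O-])c(C(F)(F)F)c2)C(=S)N1c1cccc(S(F)(F)(F)(F)F)c1` is built on a different core, and how the two cores differ is not broken down here. In this assay compound 3 gives 100000 nM, the highest of the three numbers.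

Compound 4 `CC1(C)C(=O)N(c2ccc(C#N)c(C(F)(F)F)c2)C(=S)N1c1cccc(S(F)(F)(F)(F)F)c1` stands to compound 3 as compound 1 stands to compound 2: cyano in place of nitro on an aromatic carbon. This is the same kind of change, not the same one: in compound 1 the entering group sits meta to a trifluoromethyl group, whereas in compound 4 it sits ortho to a trifluoromethyl group. Among the compounds with values here, the one measured example of this swap, on the other core, lies within the scatter, so the expected step is a 1.3-fold lower number from compound 3 to compound 4 (0.10 log units; within the scatter), set beside a 1.2-fold lower number from compound 2 to compound 1 (0.07 log units; within the scatter). That expectation rests on compound 3 starting from 100000 nM and on the swap having shown nothing beyond the scatter. Compound 4 is therefore expected to give 80000 nM, most likely between 30000 nM and 150000 nM.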

Compound 4, half-maximal inhibitory concentration: 100000 nM
Compound 4: middle estimate off by 1.3-fold (0.10 log units), on the low side; low and high end bracket the measured number.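

In this assay, putting cyano in place of nitro on an aromatic carbon, here ortho to a trifluoromethyl group, gives no change at the digits printed from compound 3 to compound 4 (within the scatter). Set beside the one earlier example, the swap reads the same on both cores, so for these two pairs a medicinal chemist could treat nitrile and nitro as interchangeable on this read-out: the same change on two cores in this assay, a 1.2-fold lower number (0.07 log units; within the scatter) from compound 2 to compound 1 and no change at the digits printed (within the scatter) from compound 3 to compound 4, 1.2-fold (0.07 log units) apart, within the scatter of two such steps

Within the data shown here, this agreement shows only that the swap moved the number by no more than the usual scatter in two pairs of compounds; it does not show that the swap would behave the same way on a third core, or why the two groups match here.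

The compounds shown leave open whether any other group on that aromatic carbon, such as an amine or a carboxylic acid, would shift the number beyond the scatter. They also leave open whether a longer chain carrying a nitrile would read the same as cyano itself.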